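Trifluoromethyl for Trifluoromethoxy on the Shared Core

This account rests on a few compounds, and the source may have more. Where it says the series, first, only, none or still open, it means among the compounds named here.

Compound 1, `Cc1cc(=O)n(-c2ccccc2OC(F)(F)F)nc1C(=O)Nc1ccc(Oc2ncnc3[nH]ccc23)cc1`, gives 22500 nM in a functional assay on PC-3 cells (Homo sapiens) for cytotoxicity, read by MTT assay, with a stated time of 72 h; a higher number here means a weaker inhibitor, a lower number a stronger inhibitor. Compound 2, `Cc1cc(=O)n(-c2ccccc2OC(F)(F)F)nc1C(=O)Nc1ccc(Oc2ncnc3c2ccn3C)cc1`, gives 5160 nM.

For the measured compounds named here, of the two measured numbers, compound 2 holds the lower one, and the step of a 4.4-fold lower number from compound 1 to compound 2 (0.64 log units; beyond the scatter) is the only measured step.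

Compound 3, `Cc1cc(=O)n(-c2ccccc2C(F)(F)F)nc1C(=O)Nc1ccc(Oc2ncnc3c2ccn3C)cc1`, differs from compound 2 by trifluoromethyl in place of trifluoromethoxy on an aromatic carbon. Going by the values given here, no measured step touches this part of the molecule, since the one step known concerns the methyl on the aromatic nitrogen, and the trifluoromethoxy group is shared by compound 1 and compound 2 alike. Among the compounds with values here, with no precedent for this exchange, no movement beyond the scatter is expected in this assay, and compound 3 is estimated at 4500 nM, within 1500 nM to 14000 nM, which amounts to an expected step of a 1.1-fold lower number from compound 2 to compound 3 (0.06 log units; within the scatter).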

Compound 3, half-maximal inhibitory concentration: 19100 nM
For compound 3 the middle estimate is 4.2-fold (0.63 log units) below the measured one; measured number above the stated range.
By their numbers in this assay, from the lowest: compound 2; then compounds 3 and 1 (each within the scatter of the next).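

Exchanging trifluoromethoxy for trifluoromethyl on the aromatic carbon gives a 3.7-fold higher number from compound 2 to compound 3 (0.57 log units; beyond the scatter) in this assay, so this part of the molecule, left unchanged between compound 1 and compound 2, does respond to change. The entering group differs from the leaving one only by the loss of the oxygen, and that small edit is enough to carry the number beyond the scatter. No measurement available here explains the shift.

The compounds shown leave open whether the same exchange would have a comparable effect with hydrogen rather than methyl on the aromatic nitrogen, as in compound 1. They also leave open how a methoxy group, a chlorine atom or a nitrile at this place on the ring would read in this assay.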